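Removing the fluorophenyl arm from a quinoline thiosemicarbazone

The source may report more compounds than this note shows. Statements on the series, on what has been measured and on what is new or still open speak of the compounds shown alone.

Compound 1 `FC(F)(F)c1ccccc1NC(=S)N/N=C/c1ccc2ccccc2n1` gives 18100 nM in a functional assay on HT-29 cells (Homo sapiens) for antiproliferative activity, read by sulforhodamine B assay, with a stated time of 72 h; a higher number here means a weaker inhibitor, a lower number a stronger inhibitor.
Compound 2 `Fc1ccccc1NC(=S)N/N=C/c1ccc2ccccc2n1` gives > 100000 nM in this assay, which is a limit of the assay, not a number.
Compound 3 `NC(=S)N/N=C/c1ccc2cccnc2n1` gives 12800 nM in this assay.

All three share a thiosemicarbazone core. Going by these compounds, compound 2 stands at the edge of what the assay can report: its value is only a limit (the limit of > 100000 nM in this assay, at which 1 of the 3 values shown sits), so its true number is unknown. Within the data shown here, the one measured step that touches it is an at least 5.5-fold higher number from compound 1 to compound 2 (0.74 log units; beyond the scatter), a change on the aromatic ring that weakened the compound.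

The step to compound 4 `NC(=S)N/N=C/c1ccc2ccccc2n1` is different in kind: hydrogen in place of 2-fluorophenyl on an amide-type nitrogen. Among the measured compounds shown here, no measured step removes this ring, so the size of the step cannot be read directly from the data. The closest guide is compound 3, which also carries only hydrogen on that nitrogen and reaches 12800 nM, although its core differs from compound 4.

On that basis compound 4 is expected to give a number rather than a limit, around 15000 nM, within 4000 nM to 80000 nM, so the estimated step is an at least 6.6-fold lower number from compound 2 to compound 4 (0.82 log units; beyond the scatter).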

Compound 4, half-maximal inhibitory concentration: 100000 nM
Beside the measured number, compound 4's estimate is 6.7-fold (0.82 log units) below it, outside the stated range (above it).
By their numbers in this assay, from the lowest: compounds 3 and 1 (each within the scatter of the next); then compound 4.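

Placing hydrogen on the amide-type nitrogen gives a measurable but high number: in this assay compound 4 gives 100000 nM, whereas compound 1, which keeps an aromatic ring there with a trifluoromethyl group on it, gives 18100 nM. So losing the ring altogether does not bring this core to the level of compound 1. For compound 2, the value > 100000 nM is a limit of the assay, not a number. Hydrogen in place of 2-fluorophenyl gives a number no higher from compound 2 to compound 4 (the limit leaves the size open), so the size of the effect of removing 2-fluorophenyl stays unknown: the limit of > 100000 nM in this assay, at which 1 of the 4 values shown sits.

The compounds shown leave open what a small group on that nitrogen, such as methyl or ethyl, would do on this core. They also leave open how a phenyl ring with no fluorine or trifluoromethyl would compare.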